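The source may hold more compounds than are shown below. What is called first, only, known or untested is meant among the compounds shown, and "the series" means these compounds.

Measured so far in a functional assay on cells (Splenocyte, Mus musculus, strain BALB/c) for inhibition, read by scintillation counting and thymidine incorporation, with a stated time of 72 h; on this read-out lower numbers stand for stronger inhibition and higher numbers for weaker inhibition:
Compound 1, `CC(/C=N/Nc1ccc([N+](=O)[O-])cc1)=N\NC(=O)c1ccccc1`: in this assay compound 1 gives > 12000 nM, which is a limit of the assay and not a number.
Compound 2, `CC(/C=N/Nc1ccc([N+](=O)[O-])cc1)=N\NC(=O)c1ccc(O)cc1`: in this assay compound 2 gives 1510 nM.
Compound 3, `CC(/C=N/Nc1ccc([N+](=O)[O-])cc1)=N\NC(=O)c1ccccc1C`: in this assay compound 3 gives 6000 nM.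

Compound 1 stands at the limit of this assay, (the limit of > 12000 nM in this assay, at which 1 of the 3 values shown sits), so no number is known for it and every step away from it can only be given as a floor. Compound 4, `CC(/C=N/Nc1ccc([N+](=O)[O-])cc1)=N\NC(=O)c1ccccc1N`, differs from compound 1 by amino in place of hydrogen on an aromatic carbon. The entering group sits on an aromatic carbon of a six-membered aromatic ring of carbon only, ortho to a large group, and brings one hydrogen-bond donor and one hydrogen-bond acceptor. Two measured steps from compound 1 bear on it: an at least 7.9-fold lower number from compound 1 to compound 2 (0.90 log units; beyond the scatter), and an at least 2.0-fold lower number from compound 1 to compound 3 (0.30 log units; that floor lies within the scatter). The two substituted compounds stand apart from one another by a 4.0-fold higher number from compound 2 to compound 3 (0.60 log units; beyond the scatter). Both measured substitutions on this ring move the number downward from the limit, one beyond the scatter and one only to a floor within it, so a downward step of a size between those two is expected for compound 4, namely an at least 3.0-fold lower number from compound 1 to compound 4 (0.47 log units; beyond the scatter). Compound 4 is estimated at 4000 nM, with a range from 1200 nM to 13000 nM.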

Compound 4, half-maximal inhibitory concentration: 4900 nM
For compound 4 the middle estimate is 1.2-fold (0.09 log units) below the measured one; the range from low to high includes it.
By their numbers in this assay, from the lowest: compound 2; then compounds 4 and 3 (each within the scatter of the next). At a limit, above all of these: compound 1.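

In this assay, amino on an aromatic carbon, ortho to a large group, gives a floor that clears the scatter, which the floor for methyl at the same place did not: an at least 2.4-fold lower number from compound 1 to compound 4 (0.38 log units; beyond the scatter). Amino and methyl at this place cannot be told apart, however, with a 1.2-fold lower number from compound 3 to compound 4 (0.09 log units; within the scatter), so the hydrogen-bond donor and acceptor that amino brings give no separation from methyl here. Compound 2 stays apart from the amino compound, with a 3.2-fold higher number from compound 2 to compound 4 (0.51 log units; beyond the scatter), but that step changes both the group and its place on the ring, so it does not rank amino against hydroxy as groups.

Going by these compounds, compound 1 is still a limit and not a number, so the full size of every step away from hydrogen stays unknown: the limit of > 12000 nM in this assay, at which 1 of the 4 values shown sits. On these data alone, whether the lower number of compound 2 belongs to hydroxy itself or to its place on the ring stays open, as does how a methoxy group or a carboxylic acid would read at the place taken by amino and methyl.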